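This account rests on a few compounds, and the source may have more. Where it says the series, first, only, none or still open, it means among the compounds named here.

Three compounds share one core and differ only in the group attached to it. In a functional assay on SGC-7901 cells (Homo sapiens) for antiproliferative activity, read by MTT assay, with a stated time of 72 h (on this read-out lower numbers stand for stronger inhibition and higher numbers for weaker inhibition), compound 1 `COc1cc(-n2cnc3ccc(-c4ccc(Cl)cc4)cc32)cc(OC)c1OC` gives 1270 nM, compound 2 `COc1cc(-n2cnc3ccc(-c4cccc(C)c4C)cc32)cc(OC)c1OC` gives 3040 nM, and compound 3 `COc1ccc(-c2ccc3ncn(-c4cc(OC)c(OC)c(OC)c4)c3c2)cc1F` gives 430 nM, the lowest of the three, reached through a 3.0-fold lower number from compound 1 to compound 3 (0.47 log units; beyond the scatter) and a 7.1-fold lower number from compound 2 to compound 3 (0.85 log units; beyond the scatter). Compound 4 `CCOc1ccc(-c2ccc3ncn(-c4cc(OC)c(OC)c(OC)c4)c3c2)cc1` differs from compound 3 by 4-ethoxyphenyl in place of 3-fluoro-4-methoxyphenyl on an aromatic carbon. Every step seen so far swaps one such group for another, and each was modest, the remaining one being a 2.4-fold higher number from compound 1 to compound 2 (0.38 log units; beyond the scatter). A swap of the same kind is therefore expected to move the number only modestly, most likely upward, because compound 3 already gives 430 nM. The estimate for compound 4 is 650 nM, within 300 nM to 1400 nM. For compound 4 this estimate means a 1.5-fold higher number from compound 3 to compound 4 (0.18 log units; within the scatter).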

Compound 4, half-maximal inhibitory concentration: 2970 nM
The estimate for compound 4 lay 4.6-fold (0.66 log units) below the measured number; the measured number lies above the stated range.
By their numbers in this assay, from the lowest: compound 3; then compound 1; then compounds 4 and 2 (each within the scatter of the next).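

In this assay, two groups with equal heavy-atom counts are far from interchangeable at this position: 4-ethoxyphenyl in place of 3-fluoro-4-methoxyphenyl gives a 6.9-fold higher number from compound 3 to compound 4 (0.84 log units; beyond the scatter) and so loses most of what compound 3 had gained. With a 1.0-fold lower number from compound 2 to compound 4 (0.01 log units; within the scatter), 4-ethoxyphenyl sits level with 2,3-dimethylphenyl, while a 2.3-fold higher number from compound 1 to compound 4 (0.37 log units; beyond the scatter) shows ethoxy giving a higher number than chloro on the same ring. No measurement available here explains these steps. On these data alone, whether the loss of fluorine or the longer ethoxy chain carries the step stays open, as does how an amine or a carboxylic acid on this ring would read.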